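From phenyl to 4-fluorophenyl on the shared core

The source may hold more compounds than are shown below. What is called first, only, known or untested is meant among the compounds shown, and "the series" means these compounds.

Among the measured compounds shown here, in a functional assay on A549 cells (Homo sapiens) for antiproliferative activity, read by MTT assay, with a stated time of 72 h (on this read-out lower numbers stand for stronger inhibition and higher numbers for weaker inhibition), compound 3 `Cc1nc(C)c(/C=C/C(=O)/C=C/c2ccccc2)nc1C` gives 12300 nM, the highest of the three numbers measured so far. Compound 1 `Cc1nc(C)c(/C=C/C(=O)/C=C/c2cccc(O)c2)nc1C` gives 4300 nM, and compound 2 `COc1ccc(/C=C/C(=O)/C=C/c2nc(C)c(C)nc2C)cc1` gives 3500 nM. Compound 4 `Cc1nc(C)c(/C=C/C(=O)/C=C/c2ccc(F)cc2)nc1C` is still unmeasured. It differs from compound 3 by fluoro in place of hydrogen on an aromatic carbon, para to a large group: fluoro in place of hydrogen on an aromatic carbon. For the measured compounds named here, two measured steps bear on this change: a 2.9-fold higher number from compound 1 to compound 3 (0.46 log units; beyond the scatter) with hydrogen in place of hydroxy, and a 3.5-fold higher number from compound 2 to compound 3 (0.55 log units; beyond the scatter) with hydrogen in place of methoxy. Neither involves fluoro, so a smaller move in the opposite direction, towards a lower number, is expected. The expected step is a 1.8-fold lower number from compound 3 to compound 4 (0.24 log units; within the scatter). The estimated value for compound 4 is 7000 nM, with an expected range from 2800 nM to 16000 nM.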

Compound 4, half-maximal inhibitory concentration: 5900 nM
Compound 4: middle estimate off by 1.2-fold (0.07 log units), on the high side; the range from low to high includes it.
By their numbers in this assay, from the lowest: compounds 2, 1 and 4 (each within the scatter of the next); then compound 3.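

In this assay, a single fluoro para to a large group is enough to lower the number beyond the scatter, with a 2.1-fold lower number from compound 3 to compound 4 (0.32 log units; beyond the scatter). That one atom leaves the number indistinguishable from that of the methoxy compound, with a 1.7-fold higher number from compound 2 to compound 4 (0.23 log units; within the scatter), and from that of the 3-hydroxyphenyl compound, with a 1.4-fold higher number from compound 1 to compound 4 (0.14 log units; within the scatter). Nothing measured here accounts for this step. Open, from the compounds shown here alone, is whether chloro, bromo or an amine in the same place would give a number like that of compound 4.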